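A few compounds are considered here, and "the series" means these few. Any claim that something is new, unique, unknown or untested is made for them only; others in the source may bear on it.

In an ADME assay on MT4 cells (Homo sapiens) for cytotoxicity, read by MTT assay, with a stated time of 5 days (a lower number here means that less compound is tolerated, a higher number that more compound is tolerated), compound 1 `COc1cc2nc([S+]([O-])CC(=O)Nc3ccc([N+](=O)[O-])cc3)nc(Nc3c(Cl)cc(/C=C/C#N)cc3Cl)c2cc1OC` gives 92800 nM as a measured number. Compound 2 `COc1cc2nc([S+]([O-])CC(=O)Nc3cccc(C#N)c3)nc(Nc3c(Cl)cc(/C=C/C#N)cc3Cl)c2cc1OC` stands at >= 70300 nM and this is a limit of the assay, not a number. For the measured compounds named here, it therefore has no exact place on the scale, and only one of the two compounds supplies a readable value.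

Compound 3 `COc1cc2nc([S+]([O-])CC(=O)Nc3c(C)cc(C)cc3C)nc(Nc3c(Cl)cc(/C=C/C#N)cc3Cl)c2cc1OC` keeps the core of compound 2 and carries 2,4,6-trimethylphenyl in place of 3-cyanophenyl on an amide-type nitrogen. Going by the values given here, the one measured step at this nitrogen is a step that the limit leaves unreadable from compound 1 to compound 2 with 3-cyanophenyl in place of 4-nitrophenyl, and it offers no size to carry over. Among the compounds with values here, no measured step therefore points in either direction, and none beyond the scatter is expected in this assay here. Compound 2 sits at the limit of >= 70300 nM in this assay, at which 1 of the 2 values shown sits, and compound 3 may be expected to end at a limit as well. The expected change is a step that the limit leaves unreadable from compound 2 to compound 3 and is estimated to stay within the scatter. Compound 3 is estimated at 75000 nM with an expected range from 30000 nM to 150000 nM in this reading.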

Compound 3, half-maximal cytotoxic concentration: 8870 nM
Compound 3: the middle estimate sits 8.5-fold (0.93 log units) above what was measured, outside the stated range (below it).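

In this assay the amide-type nitrogen now proves to be a place where the choice of aryl group can move the number, since 2,4,6-trimethylphenyl gives an at least 7.9-fold lower number from compound 2 to compound 3 (0.89 log units; beyond the scatter) and also a 10-fold lower number from compound 1 to compound 3 (1.02 log units; beyond the scatter), so that less of compound 3 is tolerated than of either earlier compound. For the compounds shown here, the earlier pair could not show this, as the step between compound 1 and compound 2 cannot be read, whereas both steps to compound 3 lie beyond the scatter and the one from the nitro-bearing compound has a definite size. Compound 2 stands at a limit, so its step gives a minimum size and not an exact one: the limit of >= 70300 nM in this assay, at which 1 of the 3 values shown sits.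

The compounds shown leave open whether the lower number goes with the three methyl groups together or with only some of them, as neither 4-methylphenyl nor 2,6-dimethylphenyl stands among them. They also leave open how an unsubstituted phenyl, a carboxylic acid on the ring or a saturated cyclohexyl group in the same place would read in this assay.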